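Chain length on the shared core: ethyl to propyl

The source may report more compounds than this note shows. Statements on the series, on what has been measured and on what is new or still open speak of the compounds shown alone.

Three measured compounds share one core and differ only in the saturated chain bound to an aromatic carbon. In a functional assay on U-937 cells (Homo sapiens) for cytotoxicity, read by MTT assay, with a stated time of 24 h (on this read-out higher numbers stand for weaker inhibition and lower numbers for stronger inhibition), compound 3 `CCCCCCCCCCn1cc(-c2nc3ccccc3cc2CC)nn1` gives 12.7 ug/mL. Compound 2 `CCCCCCCCCCn1cc(-c2nc3ccccc3cc2CCCC)nn1` gives 25.2 ug/mL in this assay, and the two values sit within the usual scatter of each other. Compound 1 `CCCCCCCCCCn1cc(-c2nc3ccccc3cc2C)nn1` gives > 100 ug/mL in this assay, which is a limit of the assay and not a number, as the limit of > 100 ug/mL in this assay, at which 1 of the 3 values shown sits, shows. The steps of an at least 7.8-fold lower number from compound 1 to compound 3 (0.89 log units; beyond the scatter) and an at least 3.9-fold lower number from compound 1 to compound 2 (0.59 log units; beyond the scatter) are beyond the scatter, whereas a 2.0-fold lower number from compound 2 to compound 3 (0.30 log units; within the scatter) is not.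

Compound 4 `CCCCCCCCCCn1cc(-c2nc3ccccc3cc2CCC)nn1` is not yet measured in this assay. It differs from compound 3 by methyl in place of hydrogen on a saturated chain carbon, two bonds along the chain from an aromatic carbon, so its chain is propyl, longer than the ethyl of compound 3 and shorter than the butyl of compound 2. The step that bears on it most directly is a 2.0-fold lower number from compound 2 to compound 3 (0.30 log units; within the scatter), which lies within the scatter. The expected step is therefore a 1.4-fold higher number from compound 3 to compound 4 (0.15 log units; within the scatter), no change beyond the scatter. Compound 4 is expected to give 18 ug/mL in this assay, with a range from 9 ug/mL to 36 ug/mL.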

Compound 4, half-maximal inhibitory concentration: 26.6 ug/mL
Estimate against measurement, compound 4: 1.5-fold (0.17 log units) below; the measured number falls inside the stated range.
By their numbers in this assay, from the lowest: compounds 3, 2 and 4 (each within the scatter of the next, the first and the last beyond it). At a limit, above all of these: compound 1.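

Methyl in place of hydrogen at this place gives a 2.1-fold higher number from compound 3 to compound 4 (0.32 log units; beyond the scatter) in this assay, a modest step that separates propyl from ethyl, while a 1.1-fold higher number from compound 2 to compound 4 (0.02 log units; within the scatter) leaves propyl and butyl indistinguishable, and compound 2 goes against any simple trend with chain length, since its step to compound 3 lies within the scatter. Propyl also stands clear of the methyl chain, with an at least 3.7-fold lower number from compound 1 to compound 4 (0.57 log units; beyond the scatter), where the value for compound 1 is a limit and not a number. Methyl in place of hydrogen therefore does not act alike at every chain length: the same change on two cores in this assay, an at least 7.8-fold lower number (0.89 log units; beyond the scatter) from compound 1 to compound 3 and a 1.1-fold lower number (0.02 log units; within the scatter) from compound 4 to compound 2, at least 7.4-fold (0.87 log units) apart, beyond the scatter of two such steps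

The compounds shown leave open how a longer chain such as hexyl or a branched chain such as isopropyl would read at this place. On these data alone, whether an amine or a carboxylic acid on the ethyl chain would keep the value of compound 3 also remains open.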